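Shortening the acyl chain: compound 4 against compound 3

The source may report more compounds than this note shows. Statements on the series, on what has been measured and on what is new or still open speak of the compounds shown alone.

Three measured compounds share one core and differ only in the acyl group on the amide nitrogen. Compound 1 `CC(=O)Nc1ccc(S(=O)(=O)Oc2ccccc2I)cc1` gives 23000 nM in a functional assay on HT-29 cells (Homo sapiens) for antiproliferative activity, read by sulforhodamine B assay, with a stated time of 48 h; on this read-out lower numbers stand for stronger inhibition and higher numbers for weaker inhibition. Compound 2 `CCCC(=O)Nc1ccc(S(=O)(=O)Oc2ccccc2I)cc1` gives 11000 nM. Compound 3 `CCCCCC(=O)Nc1ccc(S(=O)(=O)Oc2ccccc2I)cc1` gives 13000 nM, which is the second highest of the three numbers and sits close to compound 2. The steps observed so far are a 2.1-fold lower number from compound 1 to compound 2 (0.32 log units; beyond the scatter), a 1.8-fold lower number from compound 1 to compound 3 (0.25 log units; within the scatter) and a 1.2-fold higher number from compound 2 to compound 3 (0.07 log units; within the scatter); only the first of these exceeds the scatter, so lengthening the chain has changed little. Compound 4 `CC(C)C(=O)Nc1ccc(S(=O)(=O)Oc2ccccc2I)cc1` has not yet been measured. For the measured compounds named here, it differs from compound 3 by isopropyl in place of pentyl on a carbonyl carbon, a shorter, branched group where the earlier compounds carried straight chains of different lengths. Since compounds 1 to 3 span only a modest range with chains of differing length, the expected step of no change at the digits printed from compound 3 to compound 4 (within the scatter) in this assay is small and within the scatter. Compound 4 is therefore estimated at 13000 nM, with a range from 6000 nM to 28000 nM.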

Compound 4, half-maximal inhibitory concentration: 13000 nM
The estimate for compound 4 equals the measured number at the digits printed; measured number inside the range.
By their numbers in this assay, from the lowest: compounds 2, 3, 4 and 1 (each within the scatter of the next, the first and the last beyond it).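

In this assay, isopropyl in place of pentyl on the carbonyl carbon gives no change at the digits printed from compound 3 to compound 4 (within the scatter), so a branched group is tolerated here about as well as a straight chain. For the compounds shown here, the comparisons with the smaller groups give a 1.2-fold higher number from compound 2 to compound 4 (0.07 log units; within the scatter) against propyl and a 1.8-fold lower number from compound 1 to compound 4 (0.25 log units; within the scatter) against methyl , so compound 4 cannot be separated from either compound, even though it carries the first branched group in the set. No measurement available here explains why changing the shape of this group makes so little difference.

From the compounds shown here alone, whether a phenyl ring at this place, or a chain ending in an amine or a carboxylic acid, would shift the number beyond the scatter remains open. A much longer chain, such as decyl, also remains untested in the compounds shown.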